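The source may hold more compounds than are shown below. What is called first, only, known or untested is meant among the compounds shown, and "the series" means these compounds.

The measured compounds, in an assay on membranes from HeLa cells for displacement of a labelled ligand from adenosine receptor A3 (Homo sapiens), read by scintillation counting, with a stated time of 180 min, tested at 1 uM; a higher number here means more inhibition at the concentration tested (going by the name of the read-out), a lower number less inhibition:
compound 1, `CC1=C(C(=O)CC(C)C)C(c2ccoc2)NC(=O)N1`, with compound 1 giving 18%;
compound 2, `CCNC(=O)C1=C(C)NC(=O)NC1c1ccoc1`, with compound 2 giving 1%;
compound 3, `CC1=C(C(=O)NC(C)C)C(c2ccoc2)NC(=O)N1`, with compound 3 giving 3%.

Compound 3 stands second highest of the three numbers. Its nearest neighbour is compound 2, and the gap a number 2 percentage points higher from compound 2 to compound 3 (within the scatter) lies within the scatter, so the two cannot be ordered. Compound 1 is the furthest, and the gap a number 15 percentage points lower from compound 1 to compound 3 (beyond the scatter) lies beyond the scatter.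

Compound 4, `CC1=C(C(=O)OC2CCCC2)C(c2ccoc2)NC(=O)N1`, is the next compound to be measured. It differs from compound 3 in one place: cyclopentyloxy in place of isopropylamino on a carbonyl carbon.

Going by the values given here, two measured steps bear on this. a number 17 percentage points lower from compound 1 to compound 2 (beyond the scatter) and a number 15 percentage points lower from compound 1 to compound 3 (beyond the scatter) both show that putting an amino group on the carbonyl carbon in place of isobutyl lowered the number modestly. Among the compounds with values here, no measured step covers an alkoxy group on that carbon, so the direction of the present change rests on the fact that compound 4, like compound 1, carries no hydrogen-bond donor on that carbonyl. A small rise is therefore expected for compound 4 in this assay, a number 9 percentage points higher from compound 3 to compound 4 (within the scatter), probably not far beyond the scatter. Compound 4 is thus estimated at 12%, with a range from 0% to 30%.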

Compound 4, a percentage reported as inhibition, at one concentration (the size of the read-out at that concentration, not a potency): 1%
The estimate for compound 4 lay 11 percentage points above the measured number, within the range that was stated.
By their numbers in this assay, from the lowest: compounds 2, 4 and 3 (each within the scatter of the next); then compound 1.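

In this assay the change to cyclopentyloxy gives a number 2 percentage points lower from compound 3 to compound 4 (within the scatter) and likewise no change at the digits printed from compound 2 to compound 4 (within the scatter) so this group on the carbonyl carbon cannot be told apart from the two amino groups, even though it carries no hydrogen-bond donor. Set against isobutyl, it gives a number 17 percentage points lower from compound 1 to compound 4 (beyond the scatter) so the absence of a hydrogen-bond donor on this group does not by itself go with the higher number of compound 1. Nothing measured here gives a reason for this result.

The compounds shown leave open whether a longer alkyl chain, a benzyl group or a small methoxy group on that carbonyl carbon would match isobutyl or fall with the others. They also leave open how these compounds would rank in a full potency measurement, since each number comes from a single concentration.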